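An Oxime in Place of an Aldehyde at the Chain End

The compounds below may be only part of what the source reports. "The series", "measured", "known", "first", "only" and "open" are said of these compounds alone.

Measured compounds, all in an assay on A7R5 cells for displacement of a labelled ligand from Endothelin-1 receptor (Rattus norvegicus); a lower number here means a stronger inhibitor, a higher number a weaker inhibitor:
Compound 1 `COC(=O)CCCc1onc(NS(=O)(=O)c2ccc(C(C)(C)C)cc2)c1Sc1cccc(OC)c1` gives 400 nM.
Compound 2 `CCc1onc(NS(=O)(=O)c2ccc(C(C)(C)C)cc2)c1Sc1cccc(OC)c1` gives 800 nM.
Compound 3 `COc1cccc(Sc2c(NS(=O)(=O)c3ccc(C(C)(C)C)cc3)noc2CCCCC=O)c1` gives 1400 nM.

Among the three, compound 3 stands at the higher end: a 1.8-fold higher number from compound 2 to compound 3 (0.24 log units; within the scatter) lies within the scatter, whereas a 3.5-fold higher number from compound 1 to compound 3 (0.54 log units; beyond the scatter) lies beyond it. Compound 4 `COc1cccc(Sc2c(NS(=O)(=O)c3ccc(C(C)(C)C)cc3)noc2CCC/C=N/O)c1` differs from compound 3 in one place: a group of 3 heavy atoms (1 carbon, 1 nitrogen, 1 oxygen; no ring) in place of a group of 3 heavy atoms (2 carbon, 1 oxygen; no ring), on a saturated chain carbon, three bonds along the chain from an aromatic carbon. For the measured compounds named here, no measured step exchanges one terminal group of this chain for another of the same size with added hydrogen-bond donor and acceptor. The steps that touch this chain are a 3.5-fold higher number from compound 1 to compound 3 (0.54 log units; beyond the scatter), a modest weakening when the methoxycarbonyl gave way to formylmethyl, and a 1.8-fold higher number from compound 2 to compound 3 (0.24 log units; within the scatter), which is within the scatter. Since compound 1 sits at 400 nM with a different terminal group on the same chain, a change of at most modest size in either direction is expected, most likely toward a somewhat lower number. Compound 4 is therefore estimated at 1000 nM, within 400 nM to 3000 nM, corresponding to an expected step of a 1.4-fold lower number from compound 3 to compound 4 (0.15 log units; within the scatter).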

Compound 4, half-maximal inhibitory concentration: 1500 nM
Compound 4: middle estimate off by 1.5-fold (0.18 log units), on the low side; the measured number falls inside the stated range.
By their numbers in this assay, from the lowest: compounds 1, 2, 3 and 4 (each within the scatter of the next, the first and the last beyond it).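

In this assay, the step to the oxime end group with 1 hydrogen-bond donor and 2 hydrogen-bond acceptors gives a 1.1-fold higher number from compound 3 to compound 4 (0.03 log units; within the scatter) and, set against the unextended chain, a 1.9-fold higher number from compound 2 to compound 4 (0.27 log units; within the scatter), so neither exchange separates compound 4 from its neighbours at this saturated chain carbon. Only the methoxycarbonyl end group stands apart, with a 3.8-fold higher number from compound 1 to compound 4 (0.57 log units; beyond the scatter) as a modest step that matches the one already seen for the aldehyde. The compounds shown offer no evidence that could explain these results. They leave open whether a carboxylic acid or an amine at the end of this chain would shift the number beyond the scatter of compound 4. A longer chain ending in the methoxycarbonyl group also remains an open case.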